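A few compounds are considered here, and "the series" means these few. Any claim that something is new, unique, unknown or untested is made for them only; others in the source may bear on it.

Of the compounds shown here, two built on a shared core have so far been tested in an ADME assay on MT4 cells (Homo sapiens) for cytotoxicity, read by MTT assay, with a stated time of 5 days; a lower number here means that less compound is tolerated, a higher number that more compound is tolerated. Compound 1 `O=C1N(Cc2ccc(Cl)cc2Cl)c2cccn2S(=O)(=O)N1Cc1ccccc1` gives 218000 nM, and compound 2 `O=C1N(Cc2ccccc2)c2cccn2S(=O)(=O)N1Cc1ccccc1` gives 196000 nM. Going by the values given here, the single change between them is a 1.1-fold lower number from compound 1 to compound 2 (0.05 log units; within the scatter), phenyl in place of 2,4-dichlorophenyl on a saturated chain carbon bound to an amide-type nitrogen in a ring. Of the two numbers, compound 2's is the lower, but by a margin within the scatter, so nothing separates it from compound 1.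

Compound 3 `N#Cc1ccccc1CN1C(=O)N(Cc2ccccc2)S(=O)(=O)n2cccc21` has not yet been measured. It differs from compound 2 by cyano in place of hydrogen on an aromatic carbon. Among the compounds with values here, the only measured step bears on it indirectly: a 1.1-fold lower number from compound 1 to compound 2 (0.05 log units; within the scatter) exchanged the whole aryl group on the same benzyl position and left the number within the scatter. For a smaller change on that same group, the step is expected to be a 1.0-fold higher number from compound 2 to compound 3 (0.01 log units; within the scatter), that is, nothing beyond the scatter in either direction. Compound 3 is therefore estimated at 200000 nM, with a likely range from 100000 nM to 400000 nM.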

Compound 3, half-maximal cytotoxic concentration: > 318000 nM
Compound 3: no number, only a limit (the forecaster's own chance of this, stated with the estimate: 20%); middle value at least 1.5-fold (0.20 log units) from the limit.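

The value for compound 3 in this assay is a limit of the assay and not a number: the limit of > 318000 nM in this assay, at which 1 of the 3 values shown sits.

Compounds 1 and 2 showed only that removing the two chlorines from the benzyl group left the number within the scatter, whereas 2-cyanobenzyl now brings a different kind of group to this ring, with a nitrile on an aromatic carbon, ortho to a large group. The result is an at least 1.6-fold higher number from compound 2 to compound 3 (0.21 log units; that floor lies within the scatter), and the wider exchange gives an at least 1.4-fold higher number from compound 1 to compound 3 (0.16 log units; that floor lies within the scatter). Both floors lie within the scatter, so these steps show that this nitrile does not lower the number at this position, but they do not fix how large the real rise is, or confirm that there is one.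

The compounds shown leave open whether a nitrile elsewhere on this ring, or an amine or a carboxylic acid in its place, would behave the same way. As far as these compounds go, the second benzyl group on the shared core is also the same in all three compounds, so what a longer chain or a substituted ring there would do remains unknown.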